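The compounds below may be only part of what the source reports. "The series", "measured", "known", "first", "only" and "open" are said of these compounds alone.

Measured compounds in an in vitro ADME assay on microsomes from liver (Homo sapiens) for metabolic stability; on this read-out lower numbers stand for slow clearance and higher numbers for fast clearance:
compound 1, `O=C(NCC1CCOCC1)c1cnc(Nc2cccc(F)c2)cc1C1CC1`: "not determined" (no result reported)
compound 2, `O=C(NCC1CCOCC1)c1cnc(Nc2cccc(Br)c2)cc1C1CC1`: < 0.5 mL.min-1.g-1

Compound 2 gives only a limit in this assay, < 0.5 mL.min-1.g-1, and no single number. Among the measured compounds shown here, compound 1 carries no result in this assay, so no step between measured compounds is available; the one fixed point is the limit of < 0.5 mL.min-1.g-1 in this assay, at which 1 of the 2 values shown sits.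

Compound 3, `O=C(NCC1CCOCC1)c1cnc(Nc2cccc(OC(F)(F)F)c2)cc1C1CC1`, differs from compound 2 by trifluoromethoxy in place of bromo on an aromatic carbon. For the measured compounds named here, with no measured step to lean on, the expected step of an at least 1.2-fold higher number from compound 2 to compound 3 (0.07 log units; that floor lies within the scatter) is small, toward faster clearance, and may not exceed the usual scatter. Compound 3 is estimated at 0.6 mL.min-1.g-1, in the range 0.3 mL.min-1.g-1 to 1.5 mL.min-1.g-1.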

Compound 3, intrinsic clearance in microsomes: 1 mL.min-1.g-1
Compound 3: middle estimate off by 1.7-fold (0.22 log units), on the low side; the measured number falls inside the stated range.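

Trifluoromethoxy in place of bromo on this aromatic carbon gives the first step at this position that can be read in this assay: an at least 2.0-fold higher number from compound 2 to compound 3 (0.30 log units; that floor lies within the scatter). Only a floor is available for this step, and since it does not clear the scatter, a real change is not established. The true size of the step stays unfixed, with a limit as the only anchor: the limit of < 0.5 mL.min-1.g-1 in this assay, at which 1 of the 3 values shown sits.

On these data alone, how an amine or a carboxylic acid on this aromatic carbon would read in this assay stays open. The fluoro group of compound 1 offers no comparison, as compound 1 carries no result.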